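Ethynyl in place of thiophen-2-yl on two related cores

The compounds below may be only part of what the source reports. "The series", "measured", "known", "first", "only" and "open" are said of these compounds alone.

Measured compounds:
Compound 1 `C#Cc1cn([C@@H]2O[C@H](CO)[C@@H](O)[C@H]2O)c2ncnc(C)c12`: in a functional assay on K562 cells (Homo sapiens), read by MTT assay, with a stated time of 72 h (on this read-out lower numbers stand for stronger inhibition and higher numbers for weaker inhibition), compound 1 gives 110 nM.
Compound 2 `COc1nc(N)nc2c1c(-c1cccs1)cn2[C@@H]1O[C@H](CO)[C@@H](O)[C@H]1O`: in this assay compound 2 reaches only the limit > 20000 nM.
Compound 3 `Cc1ncnc2c1c(-c1cccs1)cn2[C@@H]1O[C@H](CO)[C@@H](O)[C@H]1O`: in this assay compound 3 reaches only the limit > 20000 nM.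

Going by the values given here, the one measured change, (ethynyl in place of thiophen-2-yl on an aromatic carbon), gives an at least 180-fold lower number from compound 3 to compound 1 (2.25 log units; beyond the scatter); its size is set by the start, because the limit of > 20000 nM in this assay, at which 2 of the 3 values shown sit, is the only information on compound 3. Compound 2 and compound 3 share the thiophen-2-yl group but differ in their cores; the difference between the two cores is not broken down here. Compound 4 `C#Cc1cn([C@@H]2O[C@H](CO)[C@@H](O)[C@H]2O)c2nc(N)nc(OC)c12` carries the same change, (ethynyl in place of thiophen-2-yl on an aromatic carbon), on the core of compound 2, at a place described in the same words. The step is expected to be an at least 10-fold lower number from compound 2 to compound 4 (1.00 log units; beyond the scatter), resting on the large gain seen in compound 1 at 110 nM, tempered by the unknown start. Compound 4 is estimated at 2000 nM, between 200 nM and 20000 nM.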

Compound 4, half-maximal inhibitory concentration: > 20000 nM
Compound 4: a limit, no number; the forecaster's own chance of this, stated with the estimate: 30%; middle value at least 10-fold (1.00 log units) from the limit.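

Compound 2 and compound 4 both stand only as limits in this assay, not as numbers, so no step can be read between them. From the compounds shown here alone, whether ethynyl in place of thiophen-2-yl changes anything on the core of compound 2 stays open.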